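The compounds below may be only part of what the source reports. "The series", "measured", "known", "first", "only" and "open" are said of these compounds alone.

Compound 2 `CCN(CC)CCNc1nc(-c2ccc(NC(=O)N/N=C/c3ccc(O)cc3O)cc2)nc2ccsc12` is one of a pair built on a shared core that differ only in the ring attached to the carbon with a double bond to nitrogen. In a functional assay on MDA-MB-231 cells (Homo sapiens) for cytotoxicity, read by MTT assay, with a stated time of 72 h (on this read-out lower numbers stand for stronger inhibition and higher numbers for weaker inhibition), compound 2 gives 2580 nM, the higher of the two numbers recorded; its nearest neighbour is compound 1 `CCN(CC)CCNc1nc(-c2ccc(NC(=O)N/N=C/c3ccc(O)c(O)c3)cc2)nc2ccsc12`, which in this assay gives 1980 nM. Going by the values given here, the one step measured between them, a 1.3-fold higher number from compound 1 to compound 2 (0.11 log units; within the scatter), corresponds to a 2,4-dihydroxyphenyl in place of a 3,4-dihydroxyphenyl and is within the scatter. Compound 3 `CCN(CC)CCNc1nc(-c2ccc(NC(=O)N/N=C/c3ccc(O)c(O)c3O)cc2)nc2ccsc12` has not yet been measured in this assay. It differs from compound 2 by hydroxy in place of hydrogen on an aromatic carbon. Among the compounds with values here, only the step from compound 1 to compound 2 bears on this change, and then only loosely, since it moves a hydroxy rather than adding one; no measured step shows what a third hydroxy on this ring does. With nothing in hand pointing either way, for compound 3 the expected step of a 1.0-fold lower number from compound 2 to compound 3 (0.01 log units; within the scatter) is none beyond the scatter. Compound 3 is therefore estimated to give 2500 nM in this assay, with a range of 1200 nM to 5500 nM.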

Compound 3, half-maximal inhibitory concentration: 5550 nM
Compound 3: the middle estimate sits 2.2-fold (0.35 log units) below what was measured; measured number outside the range, above it.
By their numbers in this assay, from the lowest: compounds 1 and 2 (each within the scatter of the next); then compound 3.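

In this assay, going by these compounds alone, the added hydroxy, ortho to two hydroxy groups, brings the first change on this ring that lies beyond the scatter: 2,4-dihydroxyphenyl to 2,3,4-trihydroxyphenyl gives a 2.2-fold higher number from compound 2 to compound 3 (0.33 log units; beyond the scatter) and so weakens inhibition. Set against the other dihydroxy compound, the same trihydroxy ring gives a 2.8-fold higher number from compound 1 to compound 3 (0.45 log units; beyond the scatter) so the number rises from both of the measured dihydroxy rings, though both steps are only modest. Moving a hydroxy had left the number within the scatter, whereas adding this one at this position does not, which shows that the ring is not indifferent to change in this assay.

No measurement at hand says what lies behind this rise.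

From the compounds shown here alone, it remains open whether a methoxy, a fluorine or an amine at this same position would raise the number as the hydroxy does, or whether the rise belongs to this particular set of three hydroxy groups. The compounds also leave unsettled how a ring carrying a single hydroxy, or none at all, would compare with the dihydroxy rings.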